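The compounds below may be only part of what the source reports. "The series", "measured", "known", "first", "only" and "open" are said of these compounds alone.

Measured in a functional assay on KB cells (Homo sapiens) for inhibition, read by MTT assay, with a stated time of 24 h, tested at 100 ug/mL; on this read-out higher numbers stand for more inhibition of growth at the one concentration tested and lower numbers for less inhibition of growth:
- compound 1 `O=C(CCCCC1CCSS1)Nc1cccc(C(F)(F)F)c1`: 80%
- compound 2 `O=C(CCCCC(S)CCS)Nc1ccccc1`: 15.8%
- compound 3 `O=C(CCCCC(S)CCS)Nc1cccc(Cl)c1`: 8.04%

In this assay, compound 3 gives 8.04%. That number lies within the scatter of compound 2 and far under the number of compound 1.

Compound 4 `O=C(CCCCC(S)CCS)Nc1cccc(C(F)(F)F)c1` keeps the rest of compound 3 and carries trifluoromethyl in place of chloro on an aromatic carbon.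

Among the compounds with values here, only one measured step bears directly on this position. Putting chloro in place of hydrogen on an aromatic carbon gave a number 7.8 percentage points lower from compound 2 to compound 3 (within the scatter), so that substitution moved the read-out by no more than the scatter. Compound 4 shares the trifluoromethyl group with compound 1 but differs from it elsewhere in the structure. Within the data shown here, no measured step separates the effect of that other difference from the effect of the group. Compound 1, at 80%, therefore justifies only a wider allowance on the upper side, not a large expected rise.

Overall, no change beyond the scatter is expected in this assay, though a small upward drift is allowed for. The estimated change is a number 6 percentage points higher from compound 3 to compound 4 (within the scatter). Compound 4 is expected at 14%, with an estimated range from 4% to 35%.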

Compound 4, percent growth inhibition at one concentration: 30.5%
Compound 4: the middle estimate sits 16.5 percentage points below what was measured; the range from low to high includes it.
By their numbers in this assay, from the lowest: compounds 3 and 2 (each within the scatter of the next); then compound 4; then compound 1.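

In this assay, the aromatic position, meta to a large group, proves sensitive to which group it carries: a number 22.5 percentage points higher from compound 3 to compound 4 (beyond the scatter), and a number 14.7 percentage points higher from compound 2 to compound 4 (beyond the scatter), whereas chloro in place of hydrogen had given only a number 7.8 percentage points lower from compound 2 to compound 3 (within the scatter). With trifluoromethyl held constant, the group on the saturated chain also proves to matter, and by a larger step, since exchanging the group with one five-membered non-aromatic ring with 2 hetero atoms for the open group gives a number 49.5 percentage points lower from compound 1 to compound 4 (beyond the scatter), which shows that trifluoromethyl alone does not carry the number of compound 1. No supporting measurement offers an explanation for either step.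

The compounds shown leave open whether a nitrile or a methoxy group at the same aromatic position would give a number nearer that of compound 4 or that of compound 3. They also leave open whether the ring-bearing group gives a step of similar size when the aromatic ring carries chloro or only hydrogen, so the two places cannot yet be treated as independent of each other.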